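From ethoxycarbonyl to ethylcarbamoyl on a shared core

A few compounds are considered here, and "the series" means these few. Any claim that something is new, unique, unknown or untested is made for them only; others in the source may bear on it.

Compound 1, `COc1cc(C)c(/C=C/C(C)=C/C=C(F)/C(C)=C/C(=O)O)c(C)c1C`, gives 80% in a functional assay on the whole organism (strain Hart Swiss) with Mus musculus as the target, with stated times of 5 days and 2 weeks, at a dose of 10 mg/kg by the intraperitoneal route; a higher number here means a stronger effect of the compound at the dose given, a lower number a weaker effect.
Compound 2, `CCOC(=O)/C=C(C)/C(F)=C/C=C(C)/C=C/c1c(C)cc(OC)c(C)c1C`, gives 76% in this assay.

Among the compounds with values here, compound 2 stands lowest of the two numbers so far, with compound 1 nearest, but the step of a number 4 percentage points lower from compound 1 to compound 2 (within the scatter) lies within the scatter, so the two compounds cannot be told apart on these data. Within the data shown here, that single step, ethyl in place of hydrogen on an oxygen next to a carbonyl group, is the only change measured in this set.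

Compound 3, `CCNC(=O)/C=C(C)/C(F)=C/C=C(C)/C=C/c1c(C)cc(OC)c(C)c1C`, has not yet been measured. It differs from compound 2 by ethylamino in place of ethoxy on a carbonyl carbon.

Among the measured compounds shown here, no measured step touches this kind of change. For the measured compounds named here, the one known step, a number 4 percentage points lower from compound 1 to compound 2 (within the scatter), altered the same carbonyl group without moving the number beyond the scatter, which is the only guide available. On that basis the step from compound 2 to compound 3 is expected to be small, a number 6 percentage points lower from compound 2 to compound 3 (within the scatter), with no direction that can be trusted. Compound 3 is therefore estimated at 70% in this assay, with a range from 50% to 90%.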

Compound 3, a percentage reported as activity, at one dose (the size of the read-out at that dose, not a potency): 73%
Estimate against measurement, compound 3: 3 percentage points below, within the range that was stated.
By their numbers in this assay, from the lowest: compounds 3, 2 and 1 (each within the scatter of the next).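

Ethylamino on this carbonyl carbon is the first group here that carries nitrogen and a hydrogen-bond donor, and the exchange for ethoxy, at the same count of heavy atoms, gives in this assay a number 3 percentage points lower from compound 2 to compound 3 (within the scatter). Set against hydroxy on the same carbon, the shared core with ethylamino gives a number 7 percentage points lower from compound 1 to compound 3 (within the scatter), so hydroxy, ethoxy and ethylamino at this place cannot be told apart in this read-out, and a carbonyl carbon carrying an oxygen-linked group has no distinct standing here over one carrying a nitrogen-linked group. Nothing measured on these compounds beyond this read-out bears on the result, so it stays an observation without an explanation.

The compounds shown leave open how a dimethylamino group, which has no amide hydrogen, or a longer chain such as butylamino would read on this carbonyl carbon. They also leave open whether hydroxy, ethoxy and ethylamino would stay this close at other doses, as the read-out gives the size of the effect at one dose and not a potency.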